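The source may hold more compounds than are shown below. What is called first, only, known or untested is meant among the compounds shown, and "the series" means these compounds.

Measured so far in an assay on HeLa cells for displacement of a labelled ligand from 5-hydroxytryptamine receptor 6 (Homo sapiens); a lower number here means a stronger inhibitor, a higher number a weaker inhibitor:

- Compound 1 `Cc1ccc(S(=O)(=O)c2n[nH]c3ccc(N4CCN(C)CC4)cc23)cc1` gives 4.9 nM
- Compound 2 `CN1CCN(c2ccc3c(c2)c(S(=O)(=O)c2cccc4ccccc24)nn3Cc2ccccc2)CC1` gives 2 nM
- Compound 3 `CN1CCN(c2cccc3c(S(=O)(=O)c4cccc5ccccc45)n[nH]c23)CC1` gives 4.6 nM

Compound 1 has the highest of the three numbers in this assay. Its nearest neighbour is compound 3, whose value lies within the scatter of repeated measurement, so the two cannot be told apart. Compound 2 stands further off, with a lower number that lies beyond the scatter.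

Compound 4 `CN1CCN(c2ccc3[nH]nc(S(=O)(=O)c4ccc(F)cc4)c3c2)CC1` has not yet been measured in this assay. It differs from compound 1 in one place: fluoro in place of methyl on an aromatic carbon, with the same difference, cut one bond further out, reading 4-methylphenyl to 4-fluorophenyl. Within the data shown here, no pair among the measured compounds shows this change on its own, so the size of the step cannot be read from measured data. A small step in either direction, none beyond the scatter, is expected. The change from compound 1 is estimated as a 1.1-fold lower number from compound 1 to compound 4 (0.04 log units; within the scatter). Compound 4 is expected to give 4.5 nM, with a range from 1.5 nM to 13 nM.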

Compound 4, inhibition constant: 5.2 nM
Estimate against measurement, compound 4: 1.2-fold (0.06 log units) below; measured number inside the range.
By their numbers in this assay, from the lowest: compound 2; then compounds 3, 1 and 4 (each within the scatter of the next).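

Fluoro in place of methyl on an aromatic carbon, para to a large group, gives a 1.1-fold higher number from compound 1 to compound 4 (0.03 log units; within the scatter) in this assay and so leaves compound 1 and compound 4 indistinguishable. Among these compounds, this is the only step in the set that can be read at this position, and it shows that 4-methylphenyl and 4-fluorophenyl, each carrying one heavy atom at that carbon, give values that cannot be separated. No measurement is available that bears on why the two groups give matching values.

As far as these compounds go, whether a longer chain, a methoxy group, an amine or a carboxylic acid at this carbon would leave the number equally unmoved remains open. The lower number of compound 2 also stays unexplained, since it differs from the other compounds in more than one place and its steps cannot be read.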